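The source may hold more compounds than are shown below. What is called first, only, known or untested is meant among the compounds shown, and "the series" means these compounds.

Working notes, cytotoxicity series.

Going by the values given here, compound 2 `COc1ccc(C(=O)NC(=S)N2CCc3c(OCCCCCOc4ccc(Cl)cc4)cccc32)cc1` gives 34400 nM in an ADME assay on Huh-7 cells (Homo sapiens) for cytotoxicity (on this read-out lower numbers stand for higher toxicity in this test and higher numbers for lower toxicity in this test), and holds the highest number of the two measured so far; its nearest neighbour is compound 1 `N#Cc1cccc(C(=O)NC(=S)N2CCc3c(OCCCCCOc4ccc(Cl)cc4)cccc32)c1`, which in this assay gives 9750 nM, the shared core being identical in both. Among the compounds with values here, the only measured step runs a 3.5-fold higher number from compound 1 to compound 2 (0.55 log units; beyond the scatter).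

Compound 3 `CCCC(=O)NC(=S)N1CCc2c(OCCCCCOc3ccc(Cl)cc3)cccc21` is not yet measured. It differs from compound 2 by propyl in place of 4-methoxyphenyl on a carbonyl carbon. Within the data shown here, no measured step bears directly on this change: the one step known replaces one aryl group with another on the same carbonyl carbon, whereas here the aryl group leaves altogether and a propyl enters. That step was modest, so no large movement is anticipated either way, and the estimate for compound 3 leans on compound 2 and 34400 nM with a wide range. The step from compound 2 to compound 3 is expected to be a 1.4-fold lower number from compound 2 to compound 3 (0.14 log units; within the scatter). Compound 3 is therefore estimated at 25000 nM, between 8000 nM and 70000 nM.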

Compound 3, half-maximal cytotoxic concentration: > 50000 nM
Compound 3: a limit, no number (the forecaster's own chance of this, stated with the estimate: 10%); middle value at least 2.0-fold (0.30 log units) away from the limit.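

Compound 3 gives no number, only a limit of the assay: the limit of > 50000 nM in this assay, at which 1 of the 3 values shown sits.

On the carbonyl carbon, propyl in place of 4-methoxyphenyl gives an at least 1.4-fold higher number from compound 2 to compound 3 (0.16 log units; that floor lies within the scatter), so this change cannot be called a real rise, though the loss of the aromatic ring brings no drop in the read-out. Propyl in place of 3-cyanophenyl gives an at least 5.1-fold higher number from compound 1 to compound 3 (0.70 log units; beyond the scatter), which shows that an aromatic ring at this place is not needed for the higher numbers and leaves 3-cyanophenyl as the group with the lowest number of the three.

From the compounds shown here alone, the full size of both steps stays open. Also open, going by these compounds, is how an amine, a carboxylic acid or a chain longer than propyl on this carbonyl carbon would read in this assay.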